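This account rests on a few compounds, and the source may have more. Where it says the series, first, only, none or still open, it means among the compounds named here.

Working notes on the dithiocarbamate series.

Compound 1 `O=c1c(CSC(=S)N2CCN(c3ccccc3)CC2)coc2ccccc12` gives 2900 nM in a functional assay on LM7 cells (Homo sapiens) for antiproliferative activity, read by MTT assay, with a stated time of 72 h; a higher number here means a weaker inhibitor, a lower number a stronger inhibitor. Among the compounds with values here, compound 2 `CN1CCN(C(=S)SCc2coc3ccccc3c2=O)CC1` gives 17600 nM in this assay, the higher of the two numbers so far; the step of a 6.1-fold higher number from compound 1 to compound 2 (0.78 log units; beyond the scatter) separates them. Compound 3 `CC(C)N(C(=S)SCc1coc2ccccc2c1=O)C(C)C` carries the change (diisopropylamino in place of 4-methylpiperazin-1-yl on a thiocarbonyl carbon). Within the data shown here, no measured step bears directly on this exchange; the only step on hand, from compound 1 to compound 2, swaps a substituent on the ring nitrogen rather than removing the ring. The step of a 2.0-fold lower number from compound 2 to compound 3 (0.29 log units; within the scatter) is therefore expected to be small and uncertain in direction. Compound 3 is estimated at 9000 nM, within 2500 nM to 32000 nM.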

Compound 3, half-maximal inhibitory concentration: 21900 nM
Compound 3: middle estimate off by 2.4-fold (0.39 log units), on the low side; the measured number falls inside the stated range.
By their numbers in this assay, from the lowest: compound 1; then compounds 2 and 3 (each within the scatter of the next).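

With diisopropylamino on the thiocarbonyl carbon, the ring and its second nitrogen are both gone, yet the result is a 1.2-fold higher number from compound 2 to compound 3 (0.09 log units; within the scatter). At this position, then, an open-chain amine with no ring holds the level of the 4-methylpiperazin-1-yl compound, which the ring-nitrogen exchange in the earlier pair could not show. Within the data shown here, nothing measured so far offers a reason for this. Open, on these data alone, is whether benzyl on an amine nitrogen in a ring would behave as phenyl does. Also open, as far as these compounds go, is how morpholin-4-yl or dimethylamino on the thiocarbonyl carbon would read.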